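Estimating an Azidomethyl Swap in a Cell Assay

The compounds below may be only part of what the source reports. "The series", "measured", "known", "first", "only" and "open" are said of these compounds alone.

Measured so far in an ADME assay on L1210/0 cells (Mus musculus) for cytotoxicity, with a stated time of 48 h; on this read-out higher numbers stand for weaker inhibition and lower numbers for stronger inhibition:
- Compound 1 `O=c1[nH]c(=O)n([C@H]2C[C@H](O)[C@@H](CO)O2)cc1/C=N/O`: 15500 nM
- Compound 2 `COC1=C(OC)/C(=C/Cn2cnc3c(Cl)ncnc32)OC1=O`: 14000 nM

The values of compound 1 and compound 2 lie within the usual scatter of each other, so neither compound can be ranked above the other. For the measured compounds named here, compound 1 therefore stands level with the only other measured compound, although the two structures are quite different.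

The next compound to be tested is compound 3 `[N-]=[N+]=NCc1cn([C@H]2C[C@H](O)[C@@H](CO)O2)c(=O)[nH]c1=O`. It keeps the core of compound 1 but changes one group on an aromatic carbon: a group of 4 heavy atoms (1 carbon, 3 nitrogen; no ring) in place of a group of 3 heavy atoms (1 carbon, 1 nitrogen, 1 oxygen; no ring), on an aromatic carbon. The incoming group is azidomethyl, and the group that leaves has no common name.

Going by the values given here, no two measured compounds differ in just one place, so the data offer no direct guide to the size of this step. The expectation is therefore tentative: a modest move towards a lower number, with a wide margin in either direction. The estimated change is a 2.2-fold lower number from compound 1 to compound 3 (0.35 log units; beyond the scatter). For compound 3, the estimated value is 7000 nM, with an expected range of 900 nM to 40000 nM.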

Compound 3, half-maximal inhibitory concentration: 124000 nM
For compound 3 the middle estimate is 18-fold (1.25 log units) below the measured one; the measured number lies above the stated range.
By their numbers in this assay, from the lowest: compounds 2 and 1 (each within the scatter of the next); then compound 3.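

In this assay, replacing the group on the aromatic carbon of compound 1 with azidomethyl gives an 8.0-fold higher number from compound 1 to compound 3 (0.90 log units; beyond the scatter) and so moves the compound towards weaker inhibition. For the compounds shown here, this is the first direct sign that the read-out responds to what sits at this position on the shared core, even when a group of 3 heavy atoms gives way to a group of only 4 heavy atoms, with no ring in either. No measurement shown here accounts for the shift, so the result records its size and direction but offers no explanation for them.

A single step cannot separate what the azidomethyl group itself contributes from what is lost with the group that leaves, so it remains unclear which of the two drives the change. Also open, from the compounds shown here alone, is how an amine, a carboxylic acid or a longer carbon chain on the same aromatic carbon would compare, and whether any group there could give a lower number than compound 1 does.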